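The source may report more compounds than this note shows. Statements on the series, on what has been measured and on what is new or still open speak of the compounds shown alone.

Within the data shown here, compound 2 `CCC(CC)CNC(=O)c1cc(-n2ncc(=O)[nH]c2=O)ccc1Cl` gives 1100 nM in a functional assay on cells for antagonist activity at P2X purinoceptor 7 (Homo sapiens), read by ELISA (a higher number here means a weaker inhibitor, a lower number a stronger inhibitor), the lower of the two numbers so far. Among the measured compounds shown here, compound 1 `CCCCCCNC(=O)c1cc(-n2ncc(=O)[nH]c2=O)ccc1Cl` gives 3600 nM in this assay, and the only measured step, a 3.3-fold lower number from compound 1 to compound 2 (0.51 log units; beyond the scatter), came with a branched chain in place of a straight one. Compound 3 `CCCOCCNC(=O)c1cc(-n2ncc(=O)[nH]c2=O)ccc1Cl` differs from compound 2 by propoxymethyl in place of pentan-3-yl on a saturated chain carbon bound to an amide-type nitrogen, which removes that branching again while introducing an oxygen. For the measured compounds named here, that single step is the only guide, so a modest return toward the number of compound 1 is expected, a 2.7-fold higher number from compound 2 to compound 3 (0.44 log units; beyond the scatter). Compound 3 is therefore estimated at 3000 nM, within 1000 nM to 9000 nM.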

Compound 3, half-maximal inhibitory concentration: > 5000 nM
Compound 3 ended at the assay's limit; the forecaster's own chance of this, stated with the estimate: 5%; middle value at least 1.6-fold (0.22 log units) away from the limit.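

Compound 3 stands at a limit and not at a number: the limit of > 5000 nM in this assay, at which 1 of the 3 values shown sits. Even so, the change reads as an at least 4.5-fold higher number from compound 2 to compound 3 (0.65 log units; beyond the scatter), so on a saturated chain carbon bound to an amide-type nitrogen, propoxymethyl does not keep the lower number seen with pentan-3-yl. Against the straight chain of compound 1, the result gives only an at least 1.3-fold higher number from compound 1 to compound 3 (0.14 log units; that floor lies within the scatter), so propoxy and butyl cannot be ranked here.

The compounds shown do not separate the oxygen from the lost branching. As far as these compounds go, how a branched chain carrying an ether oxygen, a cyclohexylmethyl group or a chain ending in an amine would read remains open.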